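The source may hold more compounds than are shown below. What is called first, only, known or untested is meant among the compounds shown, and "the series" means these compounds.

Measured in an ADME assay on Raji cells (Homo sapiens) for cytotoxicity, with a stated time of 72 h; on this read-out higher numbers stand for an effect only at larger amounts of compound and lower numbers for an effect already at smaller amounts:
Compound 1, `Cc1cc(NC(=O)Nc2ccc(C(=O)O)cc2)c2ccccc2n1`, gives the limit > 25000 nM.
Compound 2, `Cc1cc(NC(=O)Nc2cccc(Cl)c2)c2ccccc2n1`, gives 18000 nM.
Compound 3, `Cc1cc(NC(=O)Nc2cccc(C(N)=O)c2)c2ccccc2n1`, gives the limit > 25000 nM.

Compound 1 stands at the limit of this assay; only a limit is known for it, and compound 3 sits at the same limit, as the limit of > 25000 nM in this assay, at which 2 of the 3 values shown sit, shows. Compound 4, `CC(=O)c1ccc(NC(=O)Nc2cc(C)nc3ccccc23)cc1`, differs from compound 1 by methyl in place of hydroxy on a carbonyl carbon. Among the measured compounds shown here, no measured step touches the carbonyl carbon, so none bears directly on this change. For the measured compounds named here, the single measured step, an at least 1.3-fold higher number from compound 2 to compound 3 (0.14 log units; that floor lies within the scatter), exchanges a group on an aromatic carbon and runs into the limit, so it only confirms that the whole set sits near or at the limit in this assay. Given that, the step from compound 1 to compound 4 is expected to be small, an at least 1.2-fold lower number from compound 1 to compound 4 (0.09 log units; that floor lies within the scatter), with a reading that may again be reported only as a limit. For compound 4 the estimate in this assay is 20000 nM, between 9000 nM and 25000 nM.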

Compound 4, half-maximal effective concentration: > 25000 nM
Compound 4: only a limit was reported (the forecaster's own chance of this, stated with the estimate: 45%); middle value at least 1.2-fold (0.09 log units) away from the limit.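

In this assay compound 4 gives > 25000 nM, which is a limit. Compound 1 is also known only as a limit, so no step can be read between compound 1 and compound 4. The compounds shown leave open whether acetyl in place of carboxy changes the read-out at all, as most values rest at one point: the limit of > 25000 nM in this assay, at which 3 of the 4 values shown sit.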